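The compounds below may be only part of what the source reports. "The series", "measured", "known", "first", "only" and "open" are said of these compounds alone.

In an ADME assay on MT4 cells (Homo sapiens) for cytotoxicity, read by MTT assay (a higher number here means that more compound is tolerated, a lower number that less compound is tolerated), compound 3 `Cc1cc(C)cc(S(=O)(=O)c2c(C(=O)NCc3n[nH]c4ccccc34)[nH]c3ccc(Cl)cc23)c1` stands at > 50700 nM, which is a limit of the assay. Compound 1 `Cc1cc(C)cc(S(=O)(=O)c2c(C(=O)NCC(=O)NCc3ccncc3)[nH]c3ccc(Cl)cc23)c1` also gives only a limit, > 48900 nM. Compound 2 `Cc1cc(C)cc(S(=O)(=O)c2c(C(=O)Nc3ccnc(C#N)c3)[nH]c3ccc(Cl)cc23)c1` gives a number, 6840 nM. Compound 4 `Cc1cc(C)cc(S(=O)(=O)c2c(C(=O)NC(C)c3ccco3)[nH]c3ccc(Cl)cc23)c1` differs from compound 3 as follows: 1-(furan-2-yl)ethyl in place of (1H-indazol-3-yl)methyl on an amide-type nitrogen, with 1-(furan-2-yl)ethyl in place of (1H-indazol-3-yl)methyl on an amide-type nitrogen. The measured steps at this same place are an at least 7.1-fold lower number from compound 1 to compound 2 (0.85 log units; beyond the scatter) and an at least 7.4-fold higher number from compound 2 to compound 3 (0.86 log units; beyond the scatter), both beyond the scatter. Compound 2 thus shows that a change on this nitrogen can lower the number, though it carries a different group. A modest fall is therefore expected, an estimated at least 2.0-fold lower number from compound 3 to compound 4 (0.30 log units; that floor lies within the scatter). For compound 4 the estimated value is 25000 nM, with an expected range of 8000 nM to 55000 nM.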

Compound 4, half-maximal cytotoxic concentration: > 54700 nM
Compound 4: a limit, no number; the forecaster's own chance of this, stated with the estimate: 35%; at least 2.1-fold (0.34 log units) between middle value and limit.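

In this assay compound 4 gives > 54700 nM, which is a limit of the assay. There is an at least 7.9-fold higher number from compound 2 to compound 4 (0.90 log units; beyond the scatter), so 1-(furan-2-yl)ethyl, with no hydrogen-bond donor and no six-membered ring, joins the groups on this amide-type nitrogen that stay at a limit, and 2-cyanopyridin-4-yl remains the only group shown with a number. The steps among compounds 1, 3 and 4 cannot be read, as all three values are limits. On these data alone, whether the lower number of compound 2 goes with the nitrile or with the pyridine ring stays open, and a plain pyridin-4-yl on this nitrogen would separate the two.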